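From Methoxy to Fluoro on Compound 3

The source may report more compounds than this note shows. Statements on the series, on what has been measured and on what is new or still open speak of the compounds shown alone.

In a functional assay on SW620/5-FU cells (Homo sapiens) for cytotoxicity, read by MTT assay, with a stated time of 48 h, in the presence of a further agent that is not named here (on this read-out lower numbers stand for an effect already at smaller amounts and higher numbers for an effect only at larger amounts of compound), compound 1 `CCN(CC)c1cc(NC(=O)NNc2cc(-c3ccc(F)cc3)c3cnn(C)c3n2)cc(Cl)n1` gives 37000 nM, compound 2 `Cn1ncc2c(-c3ccc(F)cc3)cc(NNC(=O)Nc3cc(Cl)nc(OCCF)c3)nc21` gives 29300 nM and compound 3 `CCCCOc1cc(NC(=O)NNc2cc(-c3ccc(OC)cc3)c3cnn(C)c3n2)cc(Cl)n1` gives 39200 nM. Compound 3 thus stands within the scatter of both others, and the three numbers cannot be ranked. Compound 4 `CCCCOc1cc(NC(=O)NNc2cc(-c3ccc(F)cc3)c3cnn(C)c3n2)cc(Cl)n1` differs from compound 3 in one place, with fluoro in place of methoxy on an aromatic carbon, para to a large group: fluoro in place of methoxy on an aromatic carbon. Among the measured compounds shown here, no measured pair makes this exchange. For the measured compounds named here, the only measured step, a 1.3-fold lower number from compound 1 to compound 2 (0.10 log units; within the scatter), concerns a different group, with 2-fluoroethoxy in place of diethylamino, so it bears on the question only indirectly. Compound 1 at 37000 nM and compound 2 at 29300 nM both carry the 4-fluorophenyl also found in compound 4, and both lie within the scatter of compound 3 at 39200 nM. No step beyond the scatter is therefore expected in this assay. The expected step is a 1.2-fold lower number from compound 3 to compound 4 (0.07 log units; within the scatter). For compound 4 the estimated value is 33000 nM, with an expected range of 19000 nM to 56000 nM.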

Compound 4, half-maximal effective concentration: 29300 nM
Beside the measured number, compound 4's estimate is 1.1-fold (0.05 log units) above it; low and high end bracket the measured number.
By their numbers in this assay, from the lowest: compounds 2, 4, 1 and 3 (each within the scatter of the next).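

In this assay the exchange of 4-methoxyphenyl for 4-fluorophenyl now has a measured pair, and its step reads a 1.3-fold lower number from compound 3 to compound 4 (0.13 log units; within the scatter) so this change, on an aromatic carbon para to a large group, shows no effect that can be told from the scatter. Among the compounds shown here, compound 4 also ties the butoxy series to the earlier compounds: ethyl in place of fluoro on the chain reads no change at the digits printed from compound 2 to compound 4 (within the scatter) and butoxy in place of diethylamino reads a 1.3-fold lower number from compound 1 to compound 4 (0.10 log units; within the scatter) so neither exchange separates these compounds either. Nothing measured here offers a reason for these numbers.

The compounds shown leave open whether a carboxylic acid or a nitrile on this aromatic carbon would give a step beyond the scatter. They also leave open whether a longer chain in place of butoxy would do so.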